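Methoxy on the styryl ring of compound 1

The source may report more compounds than this note shows. Statements on the series, on what has been measured and on what is new or still open speak of the compounds shown alone.

Measured compounds: compound 1 `O=C(/C=C/c1ccccc1)c1ccc2c(c1)oc(=O)n2CN1CCN(Cc2ccccc2)CC1`, 9400 nM; compound 2 `COc1ccc(/C=C/C(=O)c2ccc3c(c2)oc(=O)n3CN(C)C)cc1`, 17700 nM; compound 3 `COc1ccc(/C=C/C(=O)c2ccc3c(c2)oc(=O)n3CN2CCCCC2)cc1`, 15300 nM.

In a functional assay on BV-173 cells (Homo sapiens) for cytotoxicity, read by MTT assay, with a stated time of 72 h (on this read-out lower numbers stand for stronger inhibition and higher numbers for weaker inhibition), compound 1 stands at 9400 nM, with compound 3 and compound 2 both within the scatter of it. Compound 4 `COc1ccc(/C=C/C(=O)c2ccc3c(c2)oc(=O)n3CN2CCN(Cc3ccccc3)CC2)cc1` differs from compound 1 by methoxy in place of hydrogen on an aromatic carbon. Among the measured compounds shown here, no measured pair isolates this change: the only single-point step, a 1.2-fold lower number from compound 2 to compound 3 (0.06 log units; within the scatter), concerns the amine and lies within the scatter, while compound 2 and compound 3, which already carry the methoxy group, sit within the scatter of compound 1. No step beyond the scatter is therefore expected in this assay. Compound 4 is estimated at 12000 nM, range 5000 nM to 28000 nM, an expected step of a 1.3-fold higher number from compound 1 to compound 4 (0.11 log units; within the scatter).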

Compound 4, half-maximal inhibitory concentration: 6200 nM
Beside the measured number, compound 4's estimate is 1.9-fold (0.29 log units) above it; measured number inside the range.
By their numbers in this assay, from the lowest: compounds 4, 1, 3 and 2 (each within the scatter of the next, the first and the last beyond it).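

In this assay, among the compounds shown here, the change from phenyl to 4-methoxyphenyl gives a 1.5-fold lower number from compound 1 to compound 4 (0.18 log units; within the scatter) as the first reading of methoxy in place of hydrogen with the rest of compound 1 held constant. This position, on an aromatic carbon para to a large group, therefore takes the methoxy group with no step beyond the scatter. No measurement in hand accounts for this result. On these data alone, whether a hydroxy group, a fluorine atom or a longer ethoxy group at the same place would give a step beyond the scatter remains open. Also open, as far as these compounds go, is how the same change reads with the amines of compound 2 and compound 3.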